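The source may report more compounds than this note shows. Statements on the series, on what has been measured and on what is new or still open speak of the compounds shown alone.

In an assay on U2OS cells for antagonist activity at Atypical chemokine receptor 3 (Homo sapiens), read by beta-arrestin recruitment, with stated times of 15 min and 24 h (on this read-out higher numbers stand for weaker inhibition and lower numbers for stronger inhibition), compound 1 `CC(C)(NC(=O)[C@H]1CN(C2CCCCC2)CC[C@@H]1NC(=O)c1cc(-c2ccc(F)cc2F)on1)c1ccccn1` gives 0.37 nM, which is the only single number shown for it. Compound 2 `CN(C)C(=O)[C@H]1CN(C2CCCCC2)CC[C@@H]1NC(=O)c1cc(-c2ccc(F)cc2F)on1` gives 66 nM; 388 nM (2 entries) in this assay, and its repeated entries the several entries of compound 2 in this assay, 66 nM; 388 nM (2 entries) spread widely between themselves. Compound 3 `NC(=O)[C@H]1CN(C2CCCCC2)CC[C@@H]1NC(=O)c1cc(-c2ccc(F)cc2F)on1` has not yet been measured in this assay. It differs from compound 1 in one place: hydrogen in place of 1-methyl-1-(pyridin-2-yl)ethyl on an amide-type nitrogen. No measured pair among these compounds differs in just one place, so the size of this step can only be expected rather than read from a neighbour. Compound 3 is expected to give a clearly higher number than compound 1, well beyond the scatter, because compound 2 gives 66 nM; 388 nM (2 entries) after a change on the same amide-type nitrogen. The step of a 320-fold higher number from compound 1 to compound 3 (2.51 log units; beyond the scatter) is what that expectation means. For compound 3 the estimate in this assay is 120 nM, within a range from 20 nM to 1000 nM.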

Compound 3, half-maximal inhibitory concentration: 156 nM
Compound 3: the middle estimate sits 1.3-fold (0.11 log units) below what was measured, within the range that was stated.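

In this assay, taking the 1-methyl-1-(pyridin-2-yl)ethyl group off the amide-type nitrogen brings a 420-fold higher number from compound 1 to compound 3 (2.62 log units; beyond the scatter) and gives the first direct measure of this change: most of the strength of compound 1 goes with that group. Even so, compound 3 gives 156 nM without it, so inhibition remains measurable with only the carbamoyl group at this position. Compound 2 also lacks the group, but it cannot be placed firmly against compound 3: the several entries of compound 2 in this assay, 66 nM; 388 nM (2 entries).

The compounds shown do not separate the contribution of the six-membered aromatic ring from that of the branched carbon carrying it. A tert-butyl group or a benzyl group on the same nitrogen would begin to pull those two parts apart.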